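Cytotoxicity notes on the shared-core series: chloro removal

This account rests on a few compounds, and the source may have more. Where it says the series, first, only, none or still open, it means among the compounds named here.

Compound 1 `CC(=O)N1N=C(c2ccc(-n3c(C)ccc3C)cc2)OC1c1ccccc1Cl` was tested in an ADME assay on Vero cells (Chlorocebus sabaeus) for cytotoxicity, read by MTT assay, with a stated time of 72 h (a higher number here means a weaker inhibitor, a lower number a stronger inhibitor), where compound 1 gives 201000 nM. Compound 2 `Clc1ccc(-c2nnc(-c3ccc(-n4cccc4)cc3)o2)cc1` gives 253000 nM in the same assay, and the two values lie within the scatter of each other, so no order between them can be read. For compound 3 `Cc1ccc(C)n1-c1ccc(C(=O)N/N=C/c2c(Cl)cccc2Cl)cc1` the result in this assay is "not determined" (no result reported). Compound 4 `CC(=O)N1N=C(c2ccc(-n3c(C)ccc3C)cc2)OC1c1ccccc1` has not yet been measured; it differs from compound 1 only in this: hydrogen in place of chloro on an aromatic carbon. Within the data shown here, no measured pair shows the effect of such a change here, so for the step in this assay nothing beyond the scatter is expected. Compound 4 is estimated at 220000 nM, between 100000 nM and 480000 nM, with the step from compound 1 to compound 4 expected to be a 1.1-fold higher number from compound 1 to compound 4 (0.04 log units; within the scatter).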

Compound 4, half-maximal inhibitory concentration: 190000 nM
For compound 4 the middle estimate is 1.2-fold (0.06 log units) above the measured one, and the stated range covers the measured number.
By their numbers in this assay, from the lowest: compounds 4, 1 and 2 (each within the scatter of the next).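

Going from 2-chlorophenyl to phenyl on the shared core gives a 1.1-fold lower number from compound 1 to compound 4 (0.02 log units; within the scatter) in this assay, the first measured pair for this change. At this place, on an aromatic carbon ortho to a large group, chloro can therefore give way to hydrogen with no readable shift in the number. On these data alone, whether a methoxy group, an amine or a carboxylic acid at the same place would move the number beyond the scatter remains open. No measurement at hand gives a reason for this result.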